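Cyanobenzyl to fluorobenzyl on a shared pyrazole-amide core

A few compounds are considered here, and "the series" means these few. Any claim that something is new, unique, unknown or untested is made for them only; others in the source may bear on it.

Measured compounds:
compound 1 `CC1(C)c2[nH]nc(NC(=O)c3ccccc3)c2CN1Cc1cccc(C#N)c1`: 980 nM
compound 2 `CC1(C)c2[nH]nc(NC(=O)c3ccccc3)c2CN1Cc1cccc(Br)c1`: 940 nM

Both numbers come from an assay on Sf21 cells for inhibition of high affinity nerve growth factor receptor (Homo sapiens), read by HTRF, with a stated time of 30 min, in the presence of a further agent that is not named here; on this read-out lower numbers stand for stronger inhibition and higher numbers for weaker inhibition. For the measured compounds named here, compound 1 carries the highest of the two numbers, yet the only measured step, a 1.0-fold lower number from compound 1 to compound 2 (0.02 log units; within the scatter), lies within the scatter, so the two compounds cannot be separated on this read-out.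

Compound 3 `CC1(C)c2[nH]nc(NC(=O)c3ccccc3)c2CN1Cc1ccccc1F` is the next candidate. It differs from compound 1 by 2-fluorophenyl in place of 3-cyanophenyl on a saturated chain carbon bound to an amine nitrogen in a ring. The step from compound 1 to compound 2 bears on this only in part: it exchanges one group for another on the aromatic ring while the ring itself is kept, and it produced no movement beyond the scatter. Nothing measured here touches a shift of the group to a different position, so the expectation rests on that single step alone. Compound 3 is therefore expected to show a 1.0-fold higher number from compound 1 to compound 3 (0.01 log units; within the scatter), that is, no step beyond the scatter. The estimate for compound 3 is 1000 nM, with a range from 350 nM to 2800 nM.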

Compound 3, half-maximal inhibitory concentration: 450 nM
Estimate against measurement, compound 3: 2.2-fold (0.35 log units) above; low and high end bracket the measured number.
By their numbers in this assay, from the lowest: compound 3; then compounds 2 and 1 (each within the scatter of the next).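

The benzyl group on the ring amine can move this read-out after all. Exchanging cyano for bromo in the 3-substituted series left this assay within the scatter, whereas 2-fluorobenzyl gives a 2.2-fold lower number from compound 1 to compound 3 (0.34 log units; beyond the scatter) and a 2.1-fold lower number from compound 2 to compound 3 (0.32 log units; beyond the scatter), both modest steps beyond it. Each of these steps changes the group and its place on the aromatic ring together, so they show only the combined change, and no available evidence bears on why the number falls.

The compounds shown leave open whether the lower number follows the fluorine or the 2-position, a question that 3-fluorophenyl and 2-cyanophenyl would address at this place. They also leave open how an unsubstituted phenyl, a methoxy group on the ring or a longer chain would read here.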